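This account rests on a few compounds, and the source may have more. Where it says the series, first, only, none or still open, it means among the compounds named here.

Measured compounds in a functional assay on cells for agonist activity at Free fatty acid receptor 1 (Mus musculus), read by FLIPR and calcium flux, with a stated time of 100 s; on this read-out higher numbers stand for an effect only at larger amounts of compound and lower numbers for an effect already at smaller amounts:
Compound 1, `O=C(O)C[C@@H]1CCCN1c1ccc(Oc2ccccc2)cc1`: > 16000 nM, a limit of the assay.
Compound 2, `Cc1cccc(Oc2ccc(N3CCC[C@H]3CC(=O)O)cc2)c1`: 2400 nM.
Compound 3, `O=C(O)C[C@@H]1CCCN1c1ccc(Oc2cccc(Cl)c2)cc1`: > 16000 nM, a limit of the assay.

Compound 3 therefore has no number of its own in this assay, only the limit at which it sits, and the limit of > 16000 nM in this assay, at which 2 of the 3 values shown sit, shows that compound 1 sits there too. Only compound 2 gives a measurable value. The step of an at least 6.6-fold higher number from compound 2 to compound 3 (0.82 log units; beyond the scatter) is a change from methyl to chloro at the aromatic carbon; the step of an at least 6.6-fold lower number from compound 1 to compound 2 (0.82 log units; beyond the scatter) runs the other way, from hydrogen to methyl; and a step that the two limits leave unreadable from compound 1 to compound 3 cannot be read, since both ends are limits.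

Compound 4, `CN(C)c1cccc(Oc2ccc(N3CCC[C@H]3CC(=O)O)cc2)c1`, differs from compound 3 by dimethylamino in place of chloro on an aromatic carbon. Among the measured steps, only the one from methyl gave a number, while hydrogen and chloro both left limits, so the group at that aromatic carbon clearly matters for this assay, but nothing measured says how dimethylamino will behave there. The expectation for compound 4 is therefore wide: the step of an at least 2.2-fold lower number from compound 3 to compound 4 (0.35 log units; beyond the scatter) is estimated as a return toward a measurable value, and compound 4 is expected near 7000 nM, between 2000 nM and 16000 nM.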

Compound 4, half-maximal effective concentration: > 33000 nM
Compound 4: no number, only a limit; the forecaster's own chance of this, stated with the estimate: 45%; middle value at least 4.7-fold (0.67 log units) away from the limit.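

Compound 4 sits at > 33000 nM, which is a limit of the assay. Dimethylamino in place of methyl on this aromatic carbon, meta to a large group, gives an at least 13-fold higher number from compound 2 to compound 4 (1.13 log units; beyond the scatter) in this assay, a large step that shows a measurable result here is lost with this larger group as it was with chloro in compound 3. Of the four groups shown at this place, methyl in compound 2 is now the only one with a measured number, while hydrogen in compound 1, chloro in compound 3 and dimethylamino in compound 4 all end at limits, so the steps among these three cannot be read.

The compounds shown leave open whether another group at this aromatic carbon, such as ethyl or methoxy, would also give a measured number as methyl does. They also leave open how far compound 1, compound 3 and compound 4 lie past their limits, so no order among these three can be given.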